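Three aryl groups on the triazole, all beyond the assay's reach

This account rests on a few compounds, and the source may have more. Where it says the series, first, only, none or still open, it means among the compounds named here.

Compound 2 `N#CC1=C(N)Oc2c(c3nc4ccccc4nc3c3ccccc23)C12C(=O)N(Cc1cnnn1-c1ccc(Cl)cc1)c1ccccc12` carries a 4-chlorophenyl group on the aromatic nitrogen of the triazole ring of the shared core. In a functional assay on MCF7 cells (Homo sapiens) for antiproliferative activity, read by MTT assay, with a stated time of 48 h (a higher number here means a weaker inhibitor, a lower number a stronger inhibitor), compound 2 gives only a limit, > 50000 nM, and not a number. Its two neighbours in this series are compound 1 `Cc1cccc(-n2nncc2CN2C(=O)C3(C(C#N)=C(N)Oc4c3c3nc5ccccc5nc3c3ccccc43)c3ccccc32)c1` with a 3-methylphenyl group and compound 3 `N#CC1=C(N)Oc2c(c3nc4ccccc4nc3c3ccccc23)C12C(=O)N(Cc1cnnn1-c1ccccc1Br)c1ccccc12` with a 2-bromophenyl group at the same nitrogen. In this assay compound 1 likewise gives only a limit, > 50000 nM. Compound 3 also gives only a limit in this assay, > 50000 nM. The steps a step that the two limits leave unreadable from compound 1 to compound 2, a step that the two limits leave unreadable from compound 2 to compound 3 and a step that the two limits leave unreadable from compound 1 to compound 3 therefore cannot be sized, because the limit of > 50000 nM in this assay, at which 3 of the 3 values shown sit, is where all three values sit.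

Compound 4 `COc1ccccc1-n1nncc1CN1C(=O)C2(C(C#N)=C(N)Oc3c2c2nc4ccccc4nc2c2ccccc32)c2ccccc21` differs from compound 2 in one place: 2-methoxyphenyl in place of 4-chlorophenyl on an aromatic nitrogen. The three measured steps at this aromatic nitrogen all bear on this change, and none of them gave a readable size. On that basis compound 4 is expected to stay at the same limit, and the step that the limit leaves unreadable from compound 2 to compound 4 is estimated to be unreadable for the same reason. Compound 4 is therefore estimated in this assay at 80000 nM, within 30000 nM to 300000 nM, most probably reported again as a limit rather than a number.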

Compound 4, half-maximal inhibitory concentration: > 50000 nM
Compound 4: only a limit was reported; the forecaster's own chance of this, stated with the estimate: 85%; the middle value does not contradict the limit.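

In this assay compound 4 gives only a limit, so no step from compound 1, compound 2 or compound 3 to compound 4 can be read: the limit of > 50000 nM in this assay, at which 4 of the 4 values shown sit.

The four compounds leave open how their aryl groups at this aromatic nitrogen would rank in this assay.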